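The source may report more compounds than this note shows. Statements on the series, on what has been measured and on what is new or still open speak of the compounds shown alone.

Measured compounds:
compound 1, `COc1cc(-c2cc(/C=C/C(=O)c3ccc(N)cc3)[nH]n2)cc(OC)c1OC`, 107%
compound 2, `COc1ccc(-c2cc(/C=C/C(=O)c3cc(OC)c(OC)c(OC)c3)[nH]n2)cc1OC`, 103%
compound 3, `COc1ccc(-c2cc(/C=C/C(=O)c3ccc(N)cc3)[nH]n2)cc1`, 98%

Three compounds sharing one core were run in a functional assay on IGROV-1 cells (Homo sapiens) for cytotoxicity, read by sulforhodamine B assay, with a stated time of 48 h, tested at 0.01 uM; on this read-out higher numbers stand for a weaker effect at the one concentration tested and lower numbers for a stronger effect. Compound 1 `COc1cc(-c2cc(/C=C/C(=O)c3ccc(N)cc3)[nH]n2)cc(OC)c1OC` gives 107% in this assay, the highest of the three numbers. Compound 2 `COc1ccc(-c2cc(/C=C/C(=O)c3cc(OC)c(OC)c(OC)c3)[nH]n2)cc1OC` gives 103%, and compound 3 `COc1ccc(-c2cc(/C=C/C(=O)c3ccc(N)cc3)[nH]n2)cc1` gives 98%. Both of these lie within the usual scatter of the value for compound 1, so the three numbers cannot be ranked against each other; none of them points to a marked effect at the single concentration tested.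

The account now turns to compound 4 `COc1cc(-c2cc(/C=C/C(=O)c3ccc(F)c(F)c3)[nH]n2)cc(OC)c1OC`, which has not been measured in this assay. It differs from compound 1 in one place: 3,4-difluorophenyl in place of 4-aminophenyl on a carbonyl carbon.

Within the data shown here, no step between measured compounds is available for this change. Since all three measured numbers sit close to one another, the step from compound 1 to compound 4 is expected to be none beyond the scatter, which is what a number 7 percentage points lower from compound 1 to compound 4 (within the scatter) expresses. For compound 4 a value of 100% is estimated in this assay, with a range from 85% to 115%.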

Compound 4, a percentage reported as activity, at one concentration (the size of the read-out at that concentration, not a potency): 97%
Beside the measured number, compound 4's estimate is 3 percentage points above it; measured number inside the range.
By their numbers in this assay, from the lowest: compounds 4, 3, 2 and 1 (each within the scatter of the next).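

In this assay, among these compounds, replacing 4-aminophenyl with 3,4-difluorophenyl on a carbonyl carbon gives a number 10 percentage points lower from compound 1 to compound 4 (within the scatter), the first step that can be read at this position, since the earlier compounds offered no comparison differing in one place. The exchange swaps a group with a hydrogen-bond donor and acceptor for one with neither, and it adds fluorine, yet the read-out at the single concentration tested does not register a difference beyond the usual scatter. No measurement available here explains this result.

Among the compounds shown here, with only this one step, it remains open whether the position is truly tolerant or whether the single low concentration is simply too low to reveal any difference, as none of the four compounds departs from the others beyond the scatter. As far as these compounds go, it is also open how this assay would respond if a carboxylic acid, a nitrile or a morpholine stood on the phenyl ring at this carbonyl carbon, or if the 3,4-difluorophenyl group were paired with the other substitution pattern seen on the shared core.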